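A few compounds are considered here, and "the series" means these few. Any claim that something is new, unique, unknown or untested is made for them only; others in the source may bear on it.

Within the data shown here, in a functional assay on A549 cells (Homo sapiens) for antiproliferative activity, read by MTT assay, with a stated time of 48 h (on this read-out lower numbers stand for stronger inhibition and higher numbers for weaker inhibition), compound 1 `COc1ccc2c(/C=C/C(=O)c3cc(N)c(OC)c(OC)c3)cn(C)c2c1` gives 106 nM as its value and compound 2 `COc1ccc2c(/C=C/C(=O)c3cc(OC)c(OC)c(SC)c3)cn(C)c2c1` gives 156 nM as its value, and a 1.5-fold higher number from compound 1 to compound 2 (0.17 log units; within the scatter) is the only measured step. Compound 3 `COc1cc(C(=O)/C=C/c2cn(C)c3ccccc23)cc([N+](=O)[O-])c1OC` at 1060 nM holds the highest of the three numbers, beyond the scatter from both others. Compound 4 `COc1ccc2c(/C=C/C(=O)c3cc(OC)c(OC)c([N+](=O)[O-])c3)cn(C)c2c1` is still unmeasured and differs from compound 3 by methoxy in place of hydrogen on an aromatic carbon in the core. Among the measured compounds shown here, that step has no direct measured precedent: the amino to methylsulfanyl exchange in compounds 1 and 2 occurs with this methoxy already present and leaves it unchanged. Both of those compounds carry the methoxy and give lower numbers than compound 3, but they also lack its nitro, so the two changes cannot be separated. A moderate fall in this assay is therefore expected, stopping short of the full gap. The estimated change is a 3.5-fold lower number from compound 3 to compound 4 (0.55 log units; beyond the scatter) on this read-out. For compound 4 the expected value is 300 nM with an estimated range from 90 nM to 1000 nM in these notes.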

Compound 4, half-maximal inhibitory concentration: 1020 nM
Estimate against measurement, compound 4: 3.4-fold (0.53 log units) below; the measured number lies above the stated range.
By their numbers in this assay, from the lowest: compounds 1 and 2 (each within the scatter of the next); then compounds 4 and 3 (each within the scatter of the next).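

In this assay the methoxy step reads a 1.0-fold lower number from compound 3 to compound 4 (0.02 log units; within the scatter) and so, with nitro present, methoxy in place of hydrogen on this aromatic carbon does not separate the two compounds. Among these compounds, with that methoxy held constant, the exchanges of the other group do separate compounds, as nitro in place of methylsulfanyl gives a 6.5-fold higher number from compound 2 to compound 4 (0.82 log units; beyond the scatter) and nitro in place of amino gives a 9.6-fold higher number from compound 1 to compound 4 (0.98 log units; beyond the scatter), so the gap that compound 3 showed against the earlier compounds stays with compound 4 once the methoxy is present. No measurement here accounts for either result.

Open, from the compounds shown here alone, is whether the methoxy step reads the same when amino or methylsulfanyl stands in place of nitro. Also open, going by these compounds, is how an ethoxy or a hydroxyl on this aromatic carbon, or a carboxylic acid in place of nitro, would read.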